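A few compounds are considered here, and "the series" means these few. Any claim that something is new, unique, unknown or untested is made for them only; others in the source may bear on it.

In a functional assay on MCF7 cells (Homo sapiens) for antiproliferative activity (a lower number here means a stronger inhibitor of growth, a higher number a weaker inhibitor of growth), compound 1 `COc1ccc(-c2nc3cc(F)ccc3s2)cc1` reads 490 nM and compound 2 `COc1ccc(-c2nc3cc(F)ccc3s2)cc1Br` reads 850 nM, so the two sit together (a 1.7-fold higher number from compound 1 to compound 2 (0.24 log units; within the scatter)). Compound 3 `COc1ccc(-c2nc3cc(F)ccc3s2)c(OC)c1OC`, which carries more methoxy groups, reads far lower at 23 nM on the same scale. Compound 4 `CCOc1cc(-c2nc3cc(F)ccc3s2)ccc1OC` differs from compound 2 in one place (ethoxy in place of bromo on an aromatic carbon), with ethoxy in place of bromo on an aromatic carbon. Among the measured compounds shown here, the bromo step above was small, and no measured step brings in ethoxy. Compound 3 at 23 nM hints that oxygen-linked groups can go with lower numbers, though it differs in more than one place. A moderate drop is therefore expected in this assay, as an estimated 4.3-fold lower number from compound 2 to compound 4 (0.63 log units; beyond the scatter) ahead of testing. For compound 4 the estimated value is 200 nM with an expected range from 30 nM to 1000 nM in this estimate.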

Compound 4, concentration for 50% growth inhibition: 80 nM
The estimate for compound 4 lay 2.5-fold (0.40 log units) above the measured number; the measured number falls inside the stated range.
By their numbers in this assay, from the lowest: compound 3; then compound 4; then compounds 1 and 2 (each within the scatter of the next).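

Ethoxy at this place, ortho to a methoxy group, gives a clear change where bromo gave none: in this assay the result is a 6.1-fold lower number from compound 1 to compound 4 (0.79 log units; beyond the scatter) when ethoxy replaces hydrogen and an 11-fold lower number from compound 2 to compound 4 (1.03 log units; beyond the scatter) when it replaces bromo. The position therefore does respond to substitution, and the outcome depends on which group enters rather than on simply replacing hydrogen.

Going by these compounds, whether a longer chain such as propoxy, a hydroxyl or an amine at this place would lower the number further remains open. No evidence here says why ethoxy and bromo differ.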